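Thienopyrimidine adenosine antagonists: swapping the aryl group

The compounds below may be only part of what the source reports. "The series", "measured", "known", "first", "only" and "open" are said of these compounds alone.

Compound 1 `Nc1nc(-c2ccco2)nc2sc(CN3CC=CC3)cc12`: 290 nM
Compound 2 `Nc1nc(-c2ncco2)nc2sc(CN3CC=CC3)cc12`: 3890 nM
Compound 3 `Nc1nc(-c2ncco2)nc2sc(CN3CC=CCC3)cc12`: 2960 nM

In an assay on CHO-K1 cells for antagonist activity at adenosine receptor A1 (Homo sapiens), read by a beta-galactosidase reporter, with stated times of 15 min and 6 h (on this read-out higher numbers stand for weaker inhibition and lower numbers for stronger inhibition), compound 3 stands second highest of the three numbers, close to compound 2 and well above compound 1. Compound 4 `N#Cc1ccc(-c2nc(N)c3cc(CN4CC=CCC4)sc3n2)cc1` differs from compound 3 by 4-cyanophenyl in place of 1,3-oxazol-2-yl on an aromatic carbon. Among the compounds with values here, no measured step replaces this group with a carbon-only ring; the only step at the same position, a 13-fold higher number from compound 1 to compound 2 (1.13 log units; beyond the scatter), shows that exchanging the group there can move the number a great deal. Compound 3 is therefore expected to give way to a lower number in this assay, but with wide uncertainty, estimated as a 3.7-fold lower number from compound 3 to compound 4 (0.57 log units; beyond the scatter). Compound 4 is estimated at 800 nM, with a range from 150 nM to 4500 nM.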

Compound 4, inhibition constant: 1630 nM
Beside the measured number, compound 4's estimate is 2.0-fold (0.31 log units) below it; measured number inside the range.
By their numbers in this assay, from the lowest: compound 1; then compounds 4, 3 and 2 (each within the scatter of the next, the first and the last beyond it).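

In this assay, exchanging 1,3-oxazol-2-yl for 4-cyanophenyl gives a 1.8-fold lower number from compound 3 to compound 4 (0.26 log units; within the scatter). This position therefore accepts a carbon-only six-membered aromatic ring carrying a nitrile without a change beyond the scatter, unlike the large step from furan-2-yl to 1,3-oxazol-2-yl, a 13-fold higher number from compound 1 to compound 2 (1.13 log units; beyond the scatter). Nothing given here explains why these two exchanges differ. The compounds shown leave open how a phenyl without the nitrile, or a 4-aminophenyl, would read at this position. They also leave open whether furan-2-yl would give a similarly low number on the core of compound 3.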